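Butylsulfanyl to cyclohexylamino: cytotoxicity expected for compound 3

The compounds below may be only part of what the source reports. "The series", "measured", "known", "first", "only" and "open" are said of these compounds alone.

Measured so far in an ADME assay on Akata cells (Homo sapiens) for cytotoxicity, with a stated time of 7 days; a lower number here means that less compound is tolerated, a higher number that more compound is tolerated:
compound 1, `CCCCCCCCOc1nc(N)nc2c1ncn2/C=C1/CC1(CO)CO`: > 20000 nM, a limit of the assay.
compound 2, `CCCCSc1nc(N)nc2c1ncn2/C=C1/CC1(CO)CO`: > 20000 nM, a limit of the assay.

Compound 2 stands only at a limit in this assay; no number is known for it, and no second value exists to place it against. Going by the values given here, the single measured step, a step that the two limits leave unreadable from compound 1 to compound 2, cannot be read in size or direction, since both of its ends sit at the limit of > 20000 nM in this assay, at which 2 of the 2 values shown sit. The exchange that led from compound 1 to compound 2, butylsulfanyl in place of octyloxy on an aromatic carbon, thus gives no guidance on how a change at this position moves the read-out.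

Compound 3, `Nc1nc(NC2CCCCC2)c2ncn(/C=C3/CC3(CO)CO)c2n1`, differs from compound 2 by cyclohexylamino in place of butylsulfanyl on an aromatic carbon. Among the compounds with values here, the only step on record bears on the same position, but because a step that the two limits leave unreadable from compound 1 to compound 2 is unreadable it supports neither a rise nor a fall. What remains is that every value shown so far sits at the limit of > 20000 nM in this assay, at which 2 of the 2 values shown sit. On that ground compound 3 is expected to give about 30000 nM in this assay, estimated to fall between 10000 nM and 100000 nM. The estimated step this implies, a step that the limit leaves unreadable from compound 2 to compound 3, is expected to stay within the scatter.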

Compound 3, half-maximal cytotoxic concentration: > 24000 nM
Compound 3: only a limit was reported (the forecaster's own chance of this, stated with the estimate: 75%); the middle value does not contradict the limit.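

In this assay compound 3 gives > 24000 nM, a limit of the assay. All three values are limits, and the steps joining compound 3 to compound 2 and to compound 1 cannot be read in size or direction. The compounds shown leave open at what concentration any of them becomes cytotoxic, and whether octyloxy, butylsulfanyl and cyclohexylamino on this aromatic carbon differ at all.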